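Ester to Ketone on a Shared Core

The compounds below may be only part of what the source reports. "The series", "measured", "known", "first", "only" and "open" are said of these compounds alone.

The study covers two measured compounds built on one core. Compound 1 `CCOC(=O)C1=CCCCC1S(=O)(=O)Cc1cccc(Cl)c1F` carries an ethoxycarbonyl group, and in a functional assay on RAW264.7 cells (Mus musculus), read by fluorescence (on this read-out lower numbers stand for stronger inhibition and higher numbers for weaker inhibition), compound 1 gives 12 nM. Compound 2 `COC(=O)C1=CCCCC1S(=O)(=O)Cc1ccc(F)cc1Cl` carries a methoxycarbonyl group and a differently substituted benzyl sulfone, and in this assay compound 2 gives 99 nM. Of the two numbers, compound 2 stands at the higher one, and its gap to compound 1 lies beyond the scatter, so compound 2 is the weaker inhibitor of the pair.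

Compound 3 `CCCC(=O)C1=CCCCC1S(=O)(=O)Cc1ccc(F)cc1Cl` is not yet measured. It differs from compound 2 in one place: propyl in place of methoxy on a carbonyl carbon. Within the data shown here, no measured pair in the set shows an ester being turned into a ketone, so nothing in the numbers tells how large such a step should be or in which direction it runs. The expectation is therefore cautious: the step from compound 2 to compound 3 is estimated to be small, a 1.5-fold higher number from compound 2 to compound 3 (0.18 log units; within the scatter), and may not exceed the scatter. For compound 3 in this assay the estimate is 150 nM, with a range from 40 nM to 600 nM.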

Compound 3, half-maximal inhibitory concentration: 11 nM
For compound 3 the middle estimate is 14-fold (1.13 log units) above the measured one, outside the stated range (below it).
By their numbers in this assay, from the lowest: compounds 3 and 1 (each within the scatter of the next); then compound 2.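

Among these compounds, the exchange of methoxy for propyl on the carbonyl carbon is the first change in one place alone, and in this assay it gives a 9.0-fold lower number from compound 2 to compound 3 (0.95 log units; beyond the scatter), a step beyond the scatter that makes compound 3 the stronger inhibitor of this pair. It shows that the group on this carbonyl carbon has a clear bearing on the read-out, and that on the core of compound 2 the methoxycarbonyl group can give way to propylcarbonyl without any loss of inhibition, so the ester is not required here. Nothing available explains why the number falls with this change.

With only this one pair, the compounds shown cannot separate the part played by the departure of the ester oxygen from the part played by the propyl chain itself, which a methyl or ethyl ketone, a longer chain such as butyl, or an amide at the same carbonyl carbon would begin to address. They also leave open whether the same exchange would produce a step of similar size on the differently substituted benzyl sulfone of compound 1.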